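Bromination of the ethyl chain in the chromone series

The source may hold more compounds than are shown below. What is called first, only, known or untested is meant among the compounds shown, and "the series" means these compounds.

Among the compounds with values here, the three measured members share one core, seen in compound 1 `CCc1cc(=O)c2ccc(OC)c(CBr)c2o1`. In a functional assay on KBVIN cells (Homo sapiens) for antiproliferative activity, read by sulforhodamine B assay, with a stated time of 72 h (on this read-out higher numbers stand for weaker inhibition of growth and lower numbers for stronger inhibition of growth), compound 1 gives only a limit, > 33600 nM. Compound 2 `CCOc1ccc2c(=O)cc(CC)oc2c1CBr` carries methyl in place of hydrogen on a saturated chain carbon bound to an oxygen on an aromatic ring. In this assay compound 2 likewise reaches only a limit, > 32100 nM. Compound 3 `CCc1cc(=O)c2ccc(OCC(C)C)c(CBr)c2o1` carries isopropyl at the same place. In this assay compound 3 also stops at a limit, > 29400 nM. The steps a step that the two limits leave unreadable from compound 1 to compound 2, a step that the two limits leave unreadable from compound 1 to compound 3 and a step that the two limits leave unreadable from compound 2 to compound 3 therefore cannot be read, each side resting on a limit (the limit of > 33600 nM in this assay, at which 1 of the 3 values shown sits, (the limit of > 32100 nM in this assay, at which 1 of the 3 values shown sits), (the limit of > 29400 nM in this assay, at which 1 of the 3 values shown sits)).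

Compound 4 `COc1ccc2c(=O)cc(C(C)Br)oc2c1CBr` differs from compound 1 by bromo in place of hydrogen on a saturated chain carbon bound to an aromatic carbon and a saturated chain carbon. Within the data shown here, none of the measured steps touches this chain; all concern the oxygen-bound substituent, and none yields a size or direction to carry over. With compound 1 standing at a limit, compound 4 is expected to remain near that ceiling, the step that the limit leaves unreadable from compound 1 to compound 4 being of no readable size. The estimate for compound 4 in this assay is 35000 nM, within 12000 nM to 100000 nM.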

Compound 4, concentration for 50% growth inhibition: 17000 nM
Estimate against measurement, compound 4: 2.1-fold (0.31 log units) above; the measured number falls inside the stated range.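

In this assay, within the data shown here, ethyl to 1-bromoethyl gives the only step with a readable size, an at least 1.9-fold lower number from compound 1 to compound 4 (0.29 log units; that floor lies within the scatter). Among these compounds, compound 4 is also the only one of the four compounds that gives a number rather than a limit, so this saturated chain carbon yields a reading where the changes on the oxygen-bound substituent yielded none. The step remains a floor within the usual scatter, and its full size stays unknown because compound 1 rests on a limit: the limit of > 33600 nM in this assay, at which 1 of the 4 values shown sits.

Open, from the compounds shown here alone, is whether chloro, hydroxyl or an amine on the same chain carbon would also give a number in this assay. Also open, going by these compounds, is whether 1-bromoethyl would still give a number with a longer chain on the oxygen, as in the isobutyl ether of compound 3.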